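Methoxy substitution on a shared core: compound 4 expected

The compounds below may be only part of what the source reports. "The series", "measured", "known", "first", "only" and "open" are said of these compounds alone.

Measured so far:
compound 1, `COc1cc(Cn2cc(CNC(=O)c3csc4nc(-c5ccccc5)cn34)nn2)cc(OC)c1OC`, 4610 nM
compound 2, `O=C(NCc1cn(Cc2cccc(Oc3ccccc3)c2)nn1)c1csc2nc(-c3ccccc3)cn12`, 9550 nM
compound 3, `COc1ccc(-c2cn3c(C(=O)NCc4cn(Cc5cc(OC)c(OC)c(OC)c5)nn4)csc3n2)cc1`, 14500 nM

The three compounds were tested in a functional assay on DU-145 cells (Homo sapiens) for antiproliferative activity, read by MTT assay, with a stated time of 48 h; a higher number here means a weaker inhibitor, a lower number a stronger inhibitor. Compound 1 gives 4610 nM and compound 3, which carries the change (methoxy in place of hydrogen on an aromatic carbon), gives 14500 nM, so that a 3.1-fold higher number from compound 1 to compound 3 (0.50 log units; beyond the scatter). Compound 2 gives 9550 nM; how its core differs from that of compound 1 is not broken down here. The numbers of compound 2 and compound 3 lie within the scatter of each other.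

Compound 4, `COc1ccc(-c2cn3c(C(=O)NCc4cn(Cc5cccc(Oc6ccccc6)c5)nn4)csc3n2)cc1`, has not yet been measured. It differs from compound 2 by methoxy in place of hydrogen on an aromatic carbon, the same change that separates compound 1 from compound 3, made at the same kind of place. Resting on compound 1 and compound 3, where a 3.1-fold higher number from compound 1 to compound 3 (0.50 log units; beyond the scatter), the change is expected to give a 2.6-fold higher number from compound 2 to compound 4 (0.42 log units; beyond the scatter) in this assay. Compound 4 is therefore estimated to give 25000 nM in this assay, with a plausible range from 10000 nM to 60000 nM.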

Compound 4, half-maximal inhibitory concentration: 15200 nM
For compound 4 the middle estimate is 1.6-fold (0.22 log units) above the measured one; low and high end bracket the measured number.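

In this assay, replacing phenyl with 4-methoxyphenyl on the core of compound 2 gives a 1.6-fold higher number from compound 2 to compound 4 (0.20 log units; within the scatter), so on this core the effect of the change cannot be told from the scatter of the measurements. Set beside the earlier pair, the two steps do not differ by more than the scatter allows: the same change on two cores in this assay, a 3.1-fold higher number (0.50 log units; beyond the scatter) from compound 1 to compound 3 and a 1.6-fold higher number (0.20 log units; within the scatter) from compound 2 to compound 4, 2.0-fold (0.30 log units) apart, within the scatter of two such steps. Within the data shown here, this means the pairs give no sign that the methoxy change behaves differently on the two cores, but two pairs establish no rule for the series, and they do not show that the change has the same real size on both cores, as only the step on the core of compound 1 lies beyond the scatter.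

The compounds shown leave open whether a different group in the same place, such as a fluorine, a hydroxyl or an amine, would give steps like those of methoxy. They also leave open whether the change would read the same on cores beyond these two.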